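Cytotoxicity notes on a nucleoside series: fluoromethyl to aminomethyl

The source may report more compounds than this note shows. Statements on the series, on what has been measured and on what is new or still open speak of the compounds shown alone.

Measured compounds and values in an ADME assay on Vero 76 cells (Chlorocebus sabaeus) for cytotoxicity, read by microscopy; on this read-out lower numbers stand for higher toxicity in this test and higher numbers for lower toxicity in this test:
compound 1 `CC(C)[C@@H](Nc1nc(Cl)nc2c1ncn2[C@H]1[C@H](O)[C@H](O)[C@]2(CF)C[C@H]12)C1CC1`: 36000 nM
compound 2 `OC[C@H]1O[C@@H](n2cnc3c(NC(C4CCC4)C4CCC4)ncnc32)[C@H](O)[C@@H]1O`: > 100000 nM
compound 3 `CSc1nc(N[C@H](C(C)C)C2CC2)c2ncn([C@H]3[C@H](O)[C@H](O)[C@]4(CO)C[C@H]34)c2n1`: > 100000 nM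

Among the measured compounds shown here, compound 1 is the only compound of the three with a numerical result in this assay, giving 36000 nM. For compound 2 this assay reports only a limit, > 100000 nM. For compound 3 likewise only a limit is reported, > 100000 nM. Compound 1 thus stands as the sole fixed point, the other two sitting at the limit of > 100000 nM in this assay, at which 2 of the 3 values shown sit.

Compound 4 `CC(C)[C@@H](Nc1nc(Cl)nc2c1ncn2[C@H]1[C@H](O)[C@H](O)[C@]2(CN)C[C@H]12)C1CC1` differs from compound 1 by a single change: amino in place of fluoro on a saturated chain carbon bound to a saturated ring carbon. For the measured compounds named here, no measured step between compounds that differ in one place exists here, so the effect of this change is untested. The expected step of a 1.3-fold higher number from compound 1 to compound 4 (0.10 log units; within the scatter) is small and within the scatter, with no clear direction. For compound 4 the estimated value is 45000 nM, in the range 15000 nM to 140000 nM.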

Compound 4, half-maximal cytotoxic concentration: 32000 nM
Estimate against measurement, compound 4: 1.4-fold (0.15 log units) above; measured number inside the range.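

Among the compounds shown here, the first measured step for this change in this assay reads a 1.1-fold lower number from compound 1 to compound 4 (0.05 log units; within the scatter). With amino in place of fluoro on a saturated chain carbon bound to a saturated ring carbon, this read-out does not separate fluoromethyl from aminomethyl on the core of compound 1. This rests on a single pair, and nothing shown offers a reason for the result.

From the compounds shown here alone, whether a carboxylic acid or a longer aminoalkyl chain in this place would shift the cytotoxicity number remains open. Also open, going by these compounds, is whether the same amino-for-fluoro swap would read alike on a different core.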